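The source may hold more compounds than are shown below. What is called first, only, known or untested is meant among the compounds shown, and "the series" means these compounds.

Measured compounds:
- compound 1 `CCOC(=O)[C@H](CCC(=O)O)NC(=O)c1ccc(CNc2nc3cc(N)cc(N)c3nc2-c2ccccc2)cc1`: < 100000 nM
- compound 2 `Nc1cc(N)c2nc(-c3ccccc3)c(NCc3ccc(Cl)c(Cl)c3)nc2c1`: 37200 nM
- compound 3 `CCOC(=O)[C@H](CCC(=O)O)NC(=O)c1ccc(Sc2nc3cc(N)cc(N)c3nc2-c2ccccc2)cc1`: < 100000 nM

All three were tested in a functional assay on SF-295 cells (Homo sapiens) for inhibition, read by sulforhodamine B assay, with a stated time of 48 h; on this read-out lower numbers stand for stronger inhibition of growth and higher numbers for weaker inhibition of growth. For compound 1 the entry of < 100000 nM is a limit of the test, not a number. For compound 3 the entry of < 100000 nM is likewise a limit. Compound 2 is therefore the only one of the three with a real number, 37200 nM, and it stands alone: the other two entries sit at the limit of < 100000 nM in this assay, at which 2 of the 3 values shown sit, so no ordering among the three can be drawn from them.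

Compound 4 `Nc1cc(N)c2nc(-c3ccccc3)c(NCc3ccc(F)cc3)nc2c1` has not yet been tested. It differs from compound 2 in one spot: 4-fluorophenyl in place of 3,4-dichlorophenyl on a saturated chain carbon bound to a nitrogen on an aromatic ring. Among the measured compounds shown here, since no measured pair shows what such a swap does, there is no basis for a firm direction; a small loss of growth inhibition, or none beyond the usual scatter, seems the most plausible outcome. The step from compound 2 to compound 4 is expected to be a 1.5-fold higher number from compound 2 to compound 4 (0.17 log units; within the scatter). Compound 4 is accordingly estimated at 55000 nM, in a range from 20000 nM to 100000 nM.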

Compound 4, concentration for total growth inhibition: 13500 nM
For compound 4 the middle estimate is 4.1-fold (0.61 log units) above the measured one, and the stated range ends above it.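

In this assay, replacing 3,4-dichlorobenzyl with 4-fluorobenzyl gives a 2.8-fold lower number from compound 2 to compound 4 (0.44 log units; beyond the scatter). Among the compounds shown here, this is the first single change that can be read, and it shows that the aromatic ring at this place, on a saturated chain carbon bound to a nitrogen on an aromatic ring, can be altered with a modest gain in growth inhibition rather than a loss. Nothing shown here gives a cause for this step.

From the compounds shown here alone, the swap removes two chlorines and adds one fluorine in a single move, so it remains open which part of the change carries the step, and a plain phenyl or a 4-chlorophenyl at the same place would help to separate the two. Also open, going by these compounds, is how this place would respond to a ring bearing a methoxy group or a carboxylic acid.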